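Ortho Substituents on the Urea Aryl: Toward Compound 4

The source may hold more compounds than are shown below. What is called first, only, known or untested is meant among the compounds shown, and "the series" means these compounds.

Compound 3 `CSc1ccccc1NC(=O)N[C@H]1CC[C@H](Oc2ccc(F)cc2)CC1` gives only a limit in a functional assay on CRL2813 cells (Homo sapiens) for cytotoxicity, read by sulforhodamine B assay, with a stated time of 5 days (a higher number here means a weaker inhibitor, a lower number a stronger inhibitor), namely > 20000 nM. Compound 2 `Cc1ccccc1NC(=O)N[C@H]1CC[C@H](Oc2ccc(F)cc2)CC1` likewise gives only a limit, > 20000 nM. Compound 1 `O=C(Nc1ccc(I)cc1)N[C@H]1CC[C@H](Oc2ccc(F)cc2)CC1` gives 10200 nM. The steps of an at least 1.9-fold higher number from compound 1 to compound 2 (0.29 log units; that floor lies within the scatter) and an at least 1.9-fold higher number from compound 1 to compound 3 (0.29 log units; that floor lies within the scatter) are read only as floors, and the step that the two limits leave unreadable from compound 2 to compound 3 cannot be read, since the limit of > 20000 nM in this assay, at which 2 of the 3 values shown sit, caps both of its ends. Compound 4 `O=C(Nc1ccccc1Cl)N[C@H]1CC[C@H](Oc2ccc(F)cc2)CC1` carries the change (chloro in place of methylsulfanyl on an aromatic carbon). Within the data shown here, no measured step separates a chloro from a methylsulfanyl here; the values of compound 2 and compound 3 show only that both reach the limit, so a substituent on an aromatic carbon ortho to a large group is expected to leave the number at or near that limit, a step that the limit leaves unreadable from compound 3 to compound 4. Compound 4 is therefore estimated at 25000 nM, within 8000 nM to 60000 nM.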

Compound 4, half-maximal inhibitory concentration: 9100 nM
Compound 4: the middle estimate sits 2.7-fold (0.44 log units) above what was measured; the range from low to high includes it.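

In this assay, the substituent on an aromatic carbon ortho to a large group is now seen to matter: chloro gives an at least 2.1-fold lower number from compound 3 to compound 4 (0.34 log units; beyond the scatter) and an at least 2.1-fold lower number from compound 2 to compound 4 (0.34 log units; beyond the scatter), both read as floors. Swapping 4-iodophenyl for 2-chlorophenyl gives a 1.1-fold lower number from compound 1 to compound 4 (0.05 log units; within the scatter), so the two aryl groups are not told apart here. The step from compound 2 to compound 3 still cannot be read: the limit of > 20000 nM in this assay, at which 2 of the 4 values shown sit.

On these data alone, the full size of both floors remains open. So does the effect of an amine, a carboxylic acid or a longer chain at this position.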